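Sulfonamide nitrogen series: isopropyl in place of 2-methoxyethyl

This account rests on a few compounds, and the source may have more. Where it says the series, first, only, none or still open, it means among the compounds named here.

Measured so far in a physicochemical assay for solubility, with a stated time of 24 h, tested at 30 mg/mL; a lower number here means a less soluble compound, a higher number a more soluble compound
- compound 1 `Cc1cc(COc2ccc(S(=O)(=O)NC3(C(=O)NO)CN(C(=O)C(C)C)C3)cc2)c2ccccc2n1` gives 17000000 nM
- compound 2 `Cc1cc(COc2ccc(S(=O)(=O)N(C)C3(C(=O)NO)CN(C(=O)C(C)C)C3)cc2)c2ccccc2n1` gives 56000000 nM
- compound 3 `COCCN(C1(C(=O)NO)CN(C(=O)C(C)C)C1)S(=O)(=O)c1ccc(OCc2cc(C)nc3ccccc23)cc1` gives 8900000 nM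

Two compounds stand level at the low end of these values (a 1.9-fold lower number from compound 1 to compound 3 (0.28 log units; within the scatter)), and the gap to the top value is larger (a 6.3-fold lower number from compound 2 to compound 3 (0.80 log units; beyond the scatter)). Compound 4 `Cc1cc(COc2ccc(S(=O)(=O)N(C(C)C)C3(C(=O)NO)CN(C(=O)C(C)C)C3)cc2)c2ccccc2n1` carries isopropyl in place of 2-methoxyethyl on a sulfonamide nitrogen. Among the measured compounds shown here, the steps that bear on this are those at the same nitrogen: the modest one for methyl in place of hydrogen (a 3.3-fold higher number from compound 1 to compound 2 (0.52 log units; beyond the scatter)) and the 2-methoxyethyl one above, which stays within the scatter. Neither measures isopropyl directly. Expected in this assay is a 1.6-fold higher number from compound 3 to compound 4 (0.20 log units; within the scatter) (a small upward step, not expected to clear the scatter). Compound 4 is estimated at 14000000 nM (expected range 4500000 nM to 45000000 nM).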

Compound 4, solubility: 2200000 nM
Estimate against measurement, compound 4: 6.4-fold (0.80 log units) above; measured number below the stated range.
By their numbers in this assay, from the lowest: compound 4; then compounds 3 and 1 (each within the scatter of the next); then compound 2.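

At the sulfonamide nitrogen in this assay, substitution does not act in one direction: isopropyl gives a drop beyond the scatter (a 7.7-fold lower number from compound 1 to compound 4 (0.89 log units; beyond the scatter)), whereas methyl gave a rise. Two groups on this nitrogen can therefore lie far apart, and the largest of the new steps separates methyl from isopropyl (a 25-fold lower number from compound 2 to compound 4 (1.41 log units; beyond the scatter)). Isopropyl also sits clearly under 2-methoxyethyl (a 4.0-fold lower number from compound 3 to compound 4 (0.61 log units; beyond the scatter)), so the position does not follow the order of heavy-atom counts.

As far as these compounds go, what an ethyl group, a longer straight chain or an amine-bearing chain would give at this nitrogen stays open. Nothing measured here bears on the cause of these steps.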